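The source may hold more compounds than are shown below. What is called first, only, known or untested is meant among the compounds shown, and "the series" means these compounds.

Working notes on the series. Two members have been measured in an assay for binding affinity to adenosine receptor A1 (Bos taurus); a lower number here means a stronger inhibitor, a higher number a weaker inhibitor. Compound 1 `CCCn1c(=O)c2nc(-c3ccccc3N)[nH]c2n(CCC)c1=O` gives 0.75 nM and holds the lowest of the two numbers. Compound 2 `Cn1c(=O)c2nc(-c3cccc([N+](=O)[O-])c3)[nH]c2n(C)c1=O` gives 50 nM, which lies well beyond the usual scatter from the number for compound 1; the two compounds differ in more than one place, so this gap is not assigned to any single change.

The next compound, compound 3 `CCCn1c(=O)c2nc(-c3ccc(Cl)cc3N)[nH]c2n(CCC)c1=O`, has not yet been measured in this assay. Relative to compound 1 it carries chloro in place of hydrogen on an aromatic carbon. Among the compounds with values here, no measured pair isolates this exchange, so any expectation rests on the nature of the change alone. The step of a 1.3-fold lower number from compound 1 to compound 3 (0.10 log units; within the scatter) is expected to be small, with no firm direction, and most likely to remain within the usual scatter of the assay. For compound 3 the value expected in this assay is 0.6 nM, with a range from 0.2 nM to 2 nM.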

Compound 3, half-maximal inhibitory concentration in the adenosine receptor A1 assay: 0.05 nM
Estimate against measurement, compound 3: 12-fold (1.08 log units) above; the measured number lies below the stated range.
By their numbers in the adenosine receptor A1 assay, from the lowest: compound 3; then compound 1; then compound 2.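

At this place on the aromatic ring, meta to the amino group and para to the large group, chloro in place of hydrogen proves far from a silent exchange: in the adenosine receptor A1 assay the series now has its first step that differs in one place, a 15-fold lower number from compound 1 to compound 3 (1.18 log units; beyond the scatter). The same exchange also registers in a physicochemical assay for lipophilicity (on this read-out lower numbers stand for lower lipophilicity and higher numbers for higher lipophilicity), where compound 1 gives 3.54 and compound 3 gives 4.02, so the two read-outs move together across this single pair. Stronger binding therefore comes with higher lipophilicity here, yet one pair cannot show whether the first follows from the second: the measured partition coefficient of compound 1, 3.54, and of compound 3, 4.02, a number 0.48 log units higher (beyond the scatter)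

The compounds shown leave open whether the gain belongs to chlorine itself or would also appear with a fluoro, methoxy or trifluoromethyl group at this place, and a group of low lipophilicity such as a carboxylic acid would help to separate the two read-outs. They also leave open whether the step carries over to a different substitution pattern, such as the 3-nitrophenyl compound 2 with its shorter chains.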